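Oxadiazole for Ester on the Aromatic Ring: Cytotoxicity Outlook

A few compounds are considered here, and "the series" means these few. Any claim that something is new, unique, unknown or untested is made for them only; others in the source may bear on it.

Three compounds have been measured in an ADME assay on PC-3 cells (Homo sapiens) for cytotoxicity, read by WST assay, tested at 100 uM; a lower number here means less inhibition, a higher number more inhibition at the concentration tested (going by the name of the read-out):

Compound 1 `C=Cc1cccc(C(=O)N2CCCC(C(=O)Nc3ccc(Cl)cc3)C2)c1`: 0%
Compound 2 `N#Cc1cccc(C(=O)N2CCCC(C(=O)Nc3ccc(Cl)cc3)C2)c1`: 0%
Compound 3 `COC(=O)c1cccc(C(=O)N2CCCC(C(=O)Nc3ccc(Cl)cc3)C2)c1`: 0%

Compound 3 stands level with compounds 1 and 2 at the digits shown; its nearest neighbour is compound 1 and its furthest is compound 2, and neither gap goes beyond the scatter. Compound 4 `Cc1nc(-c2cccc(C(=O)N3CCCC(C(=O)Nc4ccc(Cl)cc4)C3)c2)no1` is the next member and has not yet been measured. Its difference from compound 3 is 5-methyl-1,2,4-oxadiazol-3-yl in place of methoxycarbonyl on an aromatic carbon; a five-membered aromatic ring with three hetero atoms enters where the methoxycarbonyl stood, on the six-membered carbon-only ring, meta to a large group.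

Going by the values given here, the steps that bear on this change are the earlier swaps at the same aromatic carbon: no change at the digits printed from compound 1 to compound 2 (within the scatter), no change at the digits printed from compound 1 to compound 3 (within the scatter) and no change at the digits printed from compound 2 to compound 3 (within the scatter). Among the compounds with values here, none of them moved the read-out beyond the scatter, so a further exchange at this position is expected to produce no step either: no change at the digits printed from compound 3 to compound 4 (within the scatter). Compound 4 is therefore estimated at 0%, with a range from 0% to 10%.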

Compound 4, a percentage reported as inhibition, at one concentration (the size of the read-out at that concentration, not a potency): 0%
Compound 4: the middle estimate sits on the measured number at the digits printed, within the range that was stated.
By their numbers in this assay, from the lowest: compounds 1, 2, 3 and 4 (each within the scatter of the next).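

In this assay, a ring now stands on this aromatic carbon: the 5-methyl-1,2,4-oxadiazol-3-yl group, a five-membered aromatic ring with 3 hetero atoms, gives no change at the digits printed from compound 3 to compound 4 (within the scatter) and so extends the flat picture beyond the ringless methoxycarbonyl. The comparison with the other two groups agrees, with no change at the digits printed from compound 2 to compound 4 (within the scatter) against cyano and no change at the digits printed from compound 1 to compound 4 (within the scatter) against vinyl, so all four groups at this position read alike. No measurement shown here offers a reason for this sameness.

Going by these compounds, whether an amine, a carboxylic acid or a longer chain on this carbon would move the number in this assay stays open. So does whether any change elsewhere on the shared core would do so, as these compounds differ only at this one carbon.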